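From a branched chain to butyl on the shared core

A few compounds are considered here, and "the series" means these few. Any claim that something is new, unique, unknown or untested is made for them only; others in the source may bear on it.

Measured values in a functional assay on FaDu cells (Homo sapiens) for cytotoxicity, read by MTT assay, with a stated time of 72 h; on this read-out higher numbers stand for lower toxicity in this test and lower numbers for higher toxicity in this test:
Compound 1 `COc1ccc(NC(=O)C(=O)c2cn(C(C)(C)COCC(=O)O)c3ccccc23)cn1` gives > 10000 nM (a limit of the assay)
Compound 2 `CCn1cc(C(=O)C(=O)Nc2ccc(OC)nc2)c2ccccc21` gives 219 nM (a number)
Compound 3 `COCC(C)n1cc(C(=O)C(=O)Nc2ccc(OC)nc2)c2ccccc21` gives 12 nM (a number)

Compound 3 has the lower of the two actual numbers, and compound 2 is its nearest neighbour. The value of compound 1 is only a limit.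

Compound 4 `CCCCn1cc(C(=O)C(=O)Nc2ccc(OC)nc2)c2ccccc21` is still unmeasured. Going by the values given here, the single change butyl in place of 1-(methoxymethyl)ethyl on an aromatic nitrogen puts butyl in place of 1-(methoxymethyl)ethyl on an aromatic nitrogen.

Among the compounds with values here, all the measured steps fall on this same nitrogen. The most informative is an 18-fold lower number from compound 2 to compound 3 (1.26 log units; beyond the scatter) and it is large. The steps of an at least 45-fold lower number from compound 1 to compound 2 (1.65 log units; beyond the scatter) and an at least 830-fold lower number from compound 1 to compound 3 (2.92 log units; beyond the scatter) are larger still but start from a limit. Compound 4 lacks the methoxymethyl group of compound 3, yet its chain is longer than that of compound 2. Within the data shown here, a higher number beyond the scatter is therefore expected, but a smaller move than the one separating those two compounds. The estimated step is a 3.3-fold higher number from compound 3 to compound 4 (0.52 log units; beyond the scatter) in this assay for this change. Compound 4 is expected at 40 nM as a middle value, with an estimated range from 12 nM to 150 nM around it.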

Compound 4, concentration lethal to 50% of the cells: 18 nM
Compound 4: the middle estimate sits 2.2-fold (0.35 log units) above what was measured; the measured number falls inside the stated range.
By their numbers in this assay, from the lowest: compounds 3 and 4 (each within the scatter of the next); then compound 2. At a limit, above all of these: compound 1.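

In this assay, the oxygen of 1-(methoxymethyl)ethyl proves dispensable on this nitrogen: butyl, with no hydrogen-bond acceptor, gives a 1.5-fold higher number from compound 3 to compound 4 (0.18 log units; within the scatter) and so stays level with the branched ether chain. Chain length alone also carries a large move, since extending the ethyl group gives a 12-fold lower number from compound 2 to compound 4 (1.09 log units; beyond the scatter) without any oxygen or branch, which the earlier comparison of the ethyl and 1-(methoxymethyl)ethyl groups could not separate. Compound 1 stands at a limit of the assay, so an at least 550-fold lower number from compound 1 to compound 4 (2.74 log units; beyond the scatter) gives only a minimum size: the limit of > 10000 nM in this assay, at which 1 of the 4 values shown sits.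

The compounds shown leave open whether a longer chain such as hexyl would keep the number this low or raise it. They also leave open how an amine at the end of a butyl chain would read in this assay on this nitrogen.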